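Methylamino to ethylamino on the bicyclic core of compound 2

The source may report more compounds than this note shows. Statements on the series, on what has been measured and on what is new or still open speak of the compounds shown alone.

Two members of the series have numbers in an assay on CHO cells for displacement of a labelled ligand from adenosine receptor A3 (Homo sapiens) (on this read-out lower numbers stand for stronger inhibition and higher numbers for weaker inhibition), so far. Compound 1 `CNC(=O)[C@H]1O[C@@H](n2cnc3c(NC)nc(C#Cc4ccc(F)s4)nc32)[C@H](O)[C@@H]1O` gives 2.3 nM in this assay. Compound 2 `CNC(=O)[C@@]12C[C@@H]1[C@@H](n1cnc3c(NC)cc(C#Cc4ccc(F)s4)nc31)[C@H](O)[C@@H]2O` gives 0.896 nM in this assay, the lowest of the two numbers; the gap to compound 1 lies beyond the scatter. Among the measured compounds shown here, no pair differing in a single place has been measured, so no step size is known from data.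

Compound 3 `CCNc1cc(C#Cc2ccc(F)s2)nc2c1ncn2[C@H]1[C@H](O)[C@H](O)[C@]2(C(=O)NC)C[C@H]12` differs from compound 2 in one place: methyl in place of hydrogen on a saturated chain carbon bound to a nitrogen on an aromatic ring.

In the absence of a measured step, the expectation for compound 3 rests on compound 2 alone: its number in this assay is expected near the measured number of compound 2, 0.896 nM, with a step of a 1.8-fold higher number from compound 2 to compound 3 (0.25 log units; within the scatter) that is expected to be small, at most a modest rise, and possibly none beyond the scatter. For compound 3 the estimate in this assay is 1.6 nM, with a range from 0.5 nM to 5 nM.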

Compound 3, inhibition constant: 2.78 nM
For compound 3 the middle estimate is 1.7-fold (0.24 log units) below the measured one; the range from low to high includes it.
By their numbers in this assay, from the lowest: compound 2; then compounds 1 and 3 (each within the scatter of the next).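

In this assay, extending methylamino to ethylamino gives a 3.1-fold higher number from compound 2 to compound 3 (0.49 log units; beyond the scatter), the first single-place step measured in this series. The added methyl on a saturated chain carbon bound to a nitrogen on an aromatic ring therefore has a modest but real cost in this assay, and a larger substituent at this position is not ruled out, as compound 3 still gives 2.78 nM. No supporting data are available to account for this step.

The compounds shown leave open how the number changes with a free amine, a propylamino or a cyclopropylamino group in this place. They also leave open whether methylamino to ethylamino gives a step of similar size on the core of compound 1.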